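Moving the hydroxyl along the side chain of compound 2

A few compounds are considered here, and "the series" means these few. Any claim that something is new, unique, unknown or untested is made for them only; others in the source may bear on it.

Of the compounds shown here, two with a shared core have so far been measured in a functional assay on CCRF-CEM cells (Homo sapiens) for cytotoxicity, with a stated time of 72 h; on this read-out lower numbers stand for an effect already at smaller amounts and higher numbers for an effect only at larger amounts of compound. Compound 1 `CC(C)=CCC/C(C)=C/Cc1c(O)cc2c(c1O)C(=O)C[C@@H](c1ccc(O)c(O)c1)O2` gives 3200 nM in this assay. Compound 2 `C=C(C)C(O)CC/C(C)=C/Cc1c(O)cc2c(c1O)C(=O)C[C@@H](c1ccc(O)c(OC)c1)O2` is known only as a limit of the measurement, > 10000 nM, and no number for it exists. It therefore stands at the limit of > 10000 nM in this assay, at which 1 of the 2 values shown sits. Among the compounds with values here, compound 1 and compound 2 differ in more than one place, and no single step between them is recorded. Within the data shown here, the two values show only that compound 1 gives a number while compound 2 does not.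

Compound 3 `COc1cc([C@@H]2CC(=O)c3c(cc(O)c(C/C=C(\C)C/C=C/C(C)(C)O)c3O)O2)ccc1O` is the next compound. It is made of the same atoms as compound 2, joined differently: 3-hydroxy-3-methylbut-1-en-1-yl in place of 2-hydroxy-3-methylbut-3-en-1-yl on a saturated chain carbon bound to a double-bonded chain carbon. Among the measured compounds shown here, with no measured step of this kind available, the expectation rests on compound 2 alone, whose limit > 10000 nM leaves little room for the change to register. The step from compound 2 to compound 3 is expected to be none beyond the usual scatter, a step that the limit leaves unreadable from compound 2 to compound 3, and most likely compound 3 will again be reported only as a limit. Compound 3 is therefore estimated at 15000 nM, within a range from 5000 nM to 50000 nM.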

Compound 3, half-maximal effective concentration: > 10000 nM
Compound 3: a limit, no number; the forecaster's own chance of this, stated with the estimate: 70%; the middle value is on the limit's open side.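

In this assay compound 3 is known only as the limit > 10000 nM and not as a number. Compound 2 is also only a limit, so no step can be read between compound 2 and compound 3, and both stand at the same place: the limit of > 10000 nM in this assay, at which 2 of the 3 values shown sit. Going by these compounds, whether 3-hydroxy-3-methylbut-1-en-1-yl in place of 2-hydroxy-3-methylbut-3-en-1-yl changes the effect in this assay at all remains open.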